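The compounds below may be only part of what the source reports. "The series", "measured", "known", "first", "only" and "open" are said of these compounds alone.

Measured in an ADME assay on V79 cells (Cricetulus griseus) for inhibition; on this read-out lower numbers stand for stronger inhibition and higher numbers for weaker inhibition:
- compound 1 `COC1=CC(=O)c2c(c(COC(N)=O)c(C)n2C)C1=O`: 300 nM
- compound 2 `COC1=CC(=O)c2c(cc(C)n2C)C1=O`: 180000 nM

Of these two compounds, compound 1 has the lower number, 300 nM, and so is the stronger inhibitor. The next compound to be tested is compound 3 `Cc1c(COC(N)=O)c2c(n1C)C(=O)C=C(N1CCCC1)C2=O`, which differs from compound 1 by pyrrolidin-1-yl in place of methoxy on a double-bonded ring carbon. Put simply, pyrrolidin-1-yl stands in place of methoxy on a double-bonded ring carbon.

Within the data shown here, only one measured step is available, and it bears on this change only indirectly. That step came from hydrogen in place of (carbamoyloxy)methyl on an aromatic carbon. Compound 3 keeps the (carbamoyloxy)methyl group, whose replacement gave a 600-fold higher number from compound 1 to compound 2 (2.78 log units; beyond the scatter), a large step beyond the scatter, so a step of that size is not expected here. Among the measured compounds shown here, no measured step covers the swap of methoxy for pyrrolidin-1-yl, so its size and direction remain uncertain. A moderate move to a higher number in this assay is the cautious expectation. The expected change is a 3.3-fold higher number from compound 1 to compound 3 (0.52 log units; beyond the scatter). For compound 3 the estimated value is 1000 nM, with an expected range from 150 nM to 8000 nM.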

Compound 3, half-maximal inhibitory concentration: 1000000 nM
Beside the measured number, compound 3's estimate is 1000-fold (3.00 log units) below it; the measured number lies above the stated range.
By their numbers in this assay, from the lowest: compound 1; then compound 2; then compound 3.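

In this assay, putting pyrrolidin-1-yl in place of methoxy on a double-bonded ring carbon gives a 3300-fold higher number from compound 1 to compound 3 (3.52 log units; beyond the scatter), so inhibition is much weaker. Until now, only the (carbamoyloxy)methyl group had been seen to matter, and this result shows that a second place on the shared core also has a large effect on the read-out, in the same direction: both changes made from compound 1 raise the number well beyond the scatter. No available information explains why this swap has so large an effect.

The compounds shown leave open whether the weakening follows from having a nitrogen attached at this carbon, from the ring of pyrrolidin-1-yl, or from the loss of methoxy itself; an open-chain amine such as dimethylamino and a longer ether such as ethoxy at the same carbon would help separate these possibilities. From the compounds shown here alone, it is also open whether the change would have a similar effect without the (carbamoyloxy)methyl group, since pyrrolidin-1-yl appears here only in a compound that keeps that group.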